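The compounds below may be only part of what the source reports. "The series", "measured", "known", "first", "only" and "open" are said of these compounds alone.

Working notes on the series.

Four compounds share one core. Compound 1 is `COc1cc(Nc2nc(C(=N)Nc3ccc(N4CCN(C)CC4)cc3)cc3c(-c4ccccc4)n[nH]c23)cc(OC)c1OC` and compound 2 is `COc1ccc(Cn2nc(-c3ccccc3)c3cc(C(=N)Nc4ccc(N5CCN(C)CC5)cc4)nc(Nc4cc(OC)c(OC)c(OC)c4)c32)cc1`; both have been tested. Compound 3 is `COc1ccc(Cn2nc(-c3ccccc3)c3cc(C(=N)Nc4cccc(C(F)(F)F)c4)nc(Nc4cc(OC)c(OC)c(OC)c4)c32)cc1` and compound 4 is `COc1cc(Nc2nc(C(=N)Nc3cccc(C(F)(F)F)c3)cc3c(-c4ccccc4)n[nH]c23)cc(OC)c1OC`; compound 3 has no result reported, and compound 4 has not yet been measured.

In a functional assay on PC-3 cells (Homo sapiens) for cytotoxicity, read by MTT assay, with a stated time of 72 h (a lower number here means a stronger inhibitor, a higher number a weaker inhibitor), compound 2 gives 1240 nM, and compound 1 gives 4300 nM. The change between them is hydrogen in place of 4-methoxybenzyl on an aromatic nitrogen, and it gives a 3.5-fold higher number from compound 2 to compound 1 (0.54 log units; beyond the scatter), a modest loss on removing the group.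

Compound 3 and compound 4 differ by the same change, (hydrogen in place of 4-methoxybenzyl on an aromatic nitrogen), with the same place described around it. How the core of compound 3 differs from that of compound 2 is not broken down here. In this assay compound 3 stands as "not determined" (no result reported), so the step from compound 3 to compound 4 cannot be measured against anything directly.

Going by the values given here, the expectation for compound 4 rests on two things: the step seen from compound 2 to compound 1, a 3.5-fold higher number from compound 2 to compound 1 (0.54 log units; beyond the scatter), which suggests that compound 4 should sit at a higher number than compound 3 would, and the value of compound 1, 4300 nM, as the only measured compound carrying hydrogen on that aromatic nitrogen. Among the compounds with values here, the other part of compound 4 has no measured counterpart, so the range is kept wide. Compound 4 is estimated at 6000 nM in this assay, with an expected spread from 1500 nM to 25000 nM.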

Compound 4, half-maximal inhibitory concentration: 13900 nM
Estimate against measurement, compound 4: 2.3-fold (0.36 log units) below, and the stated range covers the measured number.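

No new step can be read from compound 4: in this assay compound 3 has no result reported, so the change from compound 3 to compound 4 has no measured starting point. No evidence is available that bears on this result. The compounds shown leave open whether hydrogen in place of 4-methoxybenzyl on the aromatic nitrogen shifts the number in the pair carrying trifluoromethyl as it does between compound 2 and compound 1.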